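The source may hold more compounds than are shown below. What is called first, only, known or untested is meant among the compounds shown, and "the series" means these compounds.

Working notes on the series. Compound 1 `Oc1ccc(-c2cccc(O)c2)cc1` is tested in a functional assay on MCF7 cells (Homo sapiens) for cytotoxicity, read by MTT assay, with a stated time of 3 days; on this read-out higher numbers stand for weaker inhibition and lower numbers for stronger inhibition. In this assay compound 1 gives only a limit, > 100 ug/mL. Compound 2 `Nc1ccc(-c2cccc(O)c2)cc1` differs from compound 1 by amino in place of hydroxy on an aromatic carbon. In this assay compound 2 also gives a limit, > 100 ug/mL. The step that the two limits leave unreadable from compound 1 to compound 2 is therefore of unreadable size, since both values sit at the limit of > 100 ug/mL in this assay, at which 2 of the 3 values shown sit.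

Compound 3 `COc1ccc(-c2cccc(O)c2)cc1OC` carries a different core; the difference between the core of compound 3 and the core of compound 1 is not broken down here. In this assay, for the measured compounds named here, compound 3 gives 48 ug/mL, the only number in the set so far.

Compound 4 `COc1ccc(-c2cccc(N)c2)cc1OC` has not yet been measured. It differs from compound 3 by amino in place of hydroxy on an aromatic carbon. Going by the values given here, this is the same kind of change as the one from compound 1 to compound 2, though not the same: in compound 2 the amino sits para to a group of 7 heavy atoms, whereas in compound 4 it sits meta to a large group. The earlier step offers no readable size to carry over.

Compound 4 is expected to show a step of a 1.1-fold lower number from compound 3 to compound 4 (0.03 log units; within the scatter). This expectation rests on compound 3 and its value of 48 ug/mL, with no measured size for this kind of change to shift it. The estimate for compound 4 is 45 ug/mL, with a range from 15 ug/mL to 100 ug/mL.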

Compound 4, half-maximal inhibitory concentration: > 100 ug/mL
Compound 4: a limit, no number; the forecaster's own chance of this, stated with the estimate: 30%; middle value at least 2.2-fold (0.34 log units) from the limit.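

In this assay, amino in place of hydroxy on the core of compound 3 gives an at least 2.0-fold higher number from compound 3 to compound 4 (0.31 log units; beyond the scatter), so on this core the change moves the read-out towards weaker inhibition by more than the usual scatter. Compound 4 gives only a limit, > 100 ug/mL, so this step has a lower bound and no measured size. The same change on the core of compound 1 cannot be read, which leaves one readable step for this change and no second size to set against it, so the notes show neither that the change carries from one core to the other nor that it fails to, and most of the series sits at the same limit: the limit of > 100 ug/mL in this assay, at which 3 of the 4 values shown sit.

Open, from the compounds shown here alone, is whether another group in place of the hydroxy on the core of compound 3, such as a carboxylic acid, a nitrile or an acetamide, would keep a readable number in this assay, or whether only the hydroxy does so among such groups. Also open, going by these compounds, is how large the step to compound 4 really is, and whether any compound on the core of compound 1 gives a number from which this change could be sized.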